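The source may report more compounds than this note shows. Statements on the series, on what has been measured and on what is new or still open speak of the compounds shown alone.

Measured in a functional assay on MT4 cells (Homo sapiens) for inhibition; a higher number here means a weaker inhibitor, a lower number a stronger inhibitor:

compound 1 `C/C(=C\COC(=O)NC(C)(C)C)C1=CC(=O)C(C)(C)O1` — 2.1 ug/mL
compound 2 `C/C(=C\C=C/C1CCCCC1)C1=CC(=O)C(C)(C)O1` — 8.4 ug/mL
compound 3 `COc1ccc(/C=C/C=C(\C)C2=CC(=O)C(C)(C)O2)cc1` — 5.7 ug/mL

Compound 1 gives the lowest number of the three in this assay and is thus the strongest inhibitor of the set; its gap to compound 3 and its larger gap to compound 2 both lie beyond the usual scatter. Compounds 2 and 3 carry a diene in place of the carbamate of compound 1, so neither pair with compound 1 is a single-point change, and nothing more is read from those two values than the order they show.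

Going by the values given here, compound 4 `C/C(=C\COC(=O)NCc1ccccc1)C1=CC(=O)C(C)(C)O1` keeps the core and the carbamate of compound 1; the one change is benzyl in place of tert-butyl on an amide-type nitrogen. Among the compounds with values here, no measured pair in the set isolates a change of this kind on the carbamate nitrogen, so the direction cannot be taken from a measured step. The carbamate, which separates compound 1 from the weaker compounds 2 and 3, is retained in compound 4, and the exchange of one substituent for another on its nitrogen is expected to move the number little, with a step of a 1.4-fold higher number from compound 1 to compound 4 (0.15 log units; within the scatter) that may well stay within the scatter, leaning if anything towards a weaker inhibitor. Compound 4 is therefore estimated at 3 ug/mL in this assay, with a range from 1.2 ug/mL to 7.5 ug/mL.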

Compound 4, half-maximal inhibitory concentration: 2 ug/mL
Beside the measured number, compound 4's estimate is 1.5-fold (0.18 log units) above it, within the range that was stated.
By their numbers in this assay, from the lowest: compounds 4 and 1 (each within the scatter of the next); then compounds 3 and 2 (each within the scatter of the next).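

On the amide-type nitrogen of the carbamate, benzyl in place of tert-butyl gives a 1.1-fold lower number from compound 1 to compound 4 (0.02 log units; within the scatter) in this assay, the first single-point step measured in this series. Benzyl brings a six-membered aromatic ring of carbon only and more heavy atoms than tert-butyl, yet compound 1 and compound 4 cannot be told apart in this assay, so this position tolerates at least this one exchange without a step beyond the scatter. The compounds shown offer no measured finding that accounts for this result.

Going by these compounds, whether that tolerance reaches beyond these two groups remains open: an amine or a carboxylic acid carried on a longer chain at the amide-type nitrogen would test it with groups of a different kind from the two hydrocarbon substituents seen so far. Going by these compounds alone, no single-point pair yet isolates the carbamate itself, so its share in the values of the series also stays unresolved, and a urea linked to the shared core in its place would address that directly.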